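The compounds below may be only part of what the source reports. "The series", "measured", "known", "first", "only" and "open" are said of these compounds alone.

compound 1 `COc1ncc(-c2ccc3c(c2)N(c2ccc(C)cc2)C(=O)CO3)cc1NS(=O)(=O)c1ccc(F)cc1`: 28300 nM
compound 2 `COc1cccc(N2C(=O)COc3ccc(-c4ccc(O)cc4)cc32)c1`: 26100 nM
compound 3 `O=C1COc2ccc(-c3cccc(NS(=O)(=O)c4ccc(F)cc4)c3)cc2N1c1ccc(Cl)cc1`: 27800 nM

These values come from a functional assay on HepG2 cells (Homo sapiens) for antiproliferative activity, read by MTT assay, with a stated time of 72 h; on this read-out higher numbers stand for weaker inhibition and lower numbers for stronger inhibition. Compound 3 stands within the scatter of both compound 1 and compound 2, so the three cannot be told apart on these numbers. Compound 4 `O=C1COc2ccc(-c3cccc(NS(=O)(=O)c4ccc(F)cc4)c3)cc2N1c1ccc(F)cc1` keeps the structure of compound 3 except for one exchange, fluoro in place of chloro on an aromatic carbon. Within the data shown here, no measured pair here differs in one place, so no direct precedent exists for this exchange. The expectation therefore starts from compound 3 at 27800 nM, and no change beyond the scatter is expected in this assay. The expected step is a 1.0-fold lower number from compound 3 to compound 4 (0.01 log units; within the scatter). For compound 4 the estimated value is 27000 nM, with an expected range of 14000 nM to 50000 nM.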

Compound 4, half-maximal inhibitory concentration: > 40000 nM
Compound 4 ended at the assay's limit (the forecaster's own chance of this, stated with the estimate: 8%); at least 1.4-fold (0.17 log units) between middle value and limit.
By their numbers in this assay, from the lowest: compounds 2, 3 and 1 (each within the scatter of the next). At a limit, above all of these: compound 4.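

In this assay, among these compounds, the exchange of 4-chlorophenyl for 4-fluorophenyl gives the first comparison here of compounds that differ in one place, with an at least 1.4-fold higher number from compound 3 to compound 4 (0.15 log units; that floor lies within the scatter). Compound 4 gives a limit rather than a number: the limit of > 40000 nM in this assay, at which 1 of the 4 values shown sits. The exchange therefore brought no stronger inhibition at this position, but whether it weakened inhibition beyond the scatter cannot be told.

The compounds shown leave open how an amine or a carboxylic acid in this place would read. They also leave open whether any group here could give clearly stronger inhibition.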